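Cyclopropylamino for isopropylamino on the shared core

The source may hold more compounds than are shown below. What is called first, only, known or untested is meant among the compounds shown, and "the series" means these compounds.

Compound 2 `CC(C)Nc1ccc(-c2ccn3c(CC4CC4)nnc3c2Cl)cc1F` stands at 20.3 nM in an assay on cells for binding affinity to metabotropic glutamate receptor 2 (Homo sapiens), read by scintillation proximity assay; on this read-out higher numbers stand for weaker binding and lower numbers for tighter binding; compound 1 `Cc1cc(Oc2ccc(-c3ccn4c(CC5CC5)nnc4c3Cl)cc2F)ccn1` gives 37.6 nM, and the two values sit within the scatter of each other, so neither is set apart. Compound 3 `Fc1cc(-c2ccn3c(CC4CC4)nnc3c2Cl)ccc1NC1CC1` carries cyclopropyl in place of isopropyl on a nitrogen on an aromatic ring. Going by the values given here, no measured step touches this nitrogen: the only step available, a 1.9-fold lower number from compound 1 to compound 2 (0.27 log units; within the scatter), exchanges a different group on the ring. The swap keeps heavy-atom count, donors and acceptors unchanged, so the expected step of a 1.0-fold lower number from compound 2 to compound 3 (0.01 log units; within the scatter) is none beyond the scatter. Compound 3 is therefore estimated at 20 nM, within 8 nM to 50 nM.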

Compound 3, dissociation constant: 12.7 nM
The estimate for compound 3 lay 1.6-fold (0.20 log units) above the measured number; the range from low to high includes it.
By their numbers in this assay, from the lowest: compounds 3, 2 and 1 (each within the scatter of the next, the first and the last beyond it).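

In the this assay series, cyclopropyl in place of isopropyl on a nitrogen on an aromatic ring gives a step that stays within the scatter (a 1.6-fold lower number from compound 2 to compound 3 (0.20 log units; within the scatter)), so the two groups cannot be told apart at this nitrogen. Cyclopropylamino in place of (2-methylpyridin-4-yl)oxy gives the first step beyond the scatter, though only a modest one (a 3.0-fold lower number from compound 1 to compound 3 (0.47 log units; beyond the scatter)). Nothing available bears on the cause of either step.

As far as these compounds go, whether a larger ring such as cyclobutyl, or a longer chain such as n-butyl, would be tolerated on this nitrogen remains open. So does the effect of replacing the amine nitrogen with an ether oxygen while keeping the cyclopropyl group.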